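The compounds below may be only part of what the source reports. "The series", "measured", "known", "first", "only" and "open" are said of these compounds alone.

Measured compounds in an assay (Cricetulus griseus) for inhibition of aldehyde dehydrogenase, mitochondrial (Homo sapiens); a lower number here means a stronger inhibitor, a higher number a weaker inhibitor:
Compound 1 `O=C(O)CCCCCCCCCCCCCCCOc1ccc2c(=O)c(-c3ccc(O)cc3)coc2c1`. In this assay compound 1 reaches only a limit, > 9000 nM.
Compound 2 `C=CCOc1ccc2c(=O)c(-c3ccc(O)cc3)coc2c1`. In this assay compound 2 gives 180 nM.

For the measured compounds named here, compound 1 stands at the limit of this assay, as the limit of > 9000 nM in this assay, at which 1 of the 2 values shown sits, records, so no number is known for it and no measured step can be drawn from it. Going by the values given here, compound 2 carries the only number in the set.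

Compound 3 `O=C(O)CCCCCCOc1ccc2c(=O)c(-c3ccc(O)cc3)coc2c1` is the next compound for this assay. It differs from compound 1 by carboxy in place of 9-carboxynonyl on a saturated chain carbon, six bonds along the chain from an oxygen on an aromatic ring. The change shortens the acid-bearing chain on the ether oxygen of the shared core while keeping the carboxy end group, so compound 3 sits between compound 1 and compound 2 in the size of that substituent.

The step of an at least 3.0-fold lower number from compound 1 to compound 3 (0.47 log units; beyond the scatter) is expected to run downward, toward a stronger inhibitor, but it starts from a limit and its size is uncertain. Compound 3 is expected to give 3000 nM, within a range from 600 nM to 15000 nM.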

Compound 3, half-maximal inhibitory concentration: 50 nM
Estimate against measurement, compound 3: 60-fold (1.78 log units) above; measured number below the stated range.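

In this assay, shortening the acid-bearing chain on the ether oxygen while keeping the carboxy end group gives an at least 180-fold lower number from compound 1 to compound 3 (2.25 log units; beyond the scatter), so chain length at this position has a large bearing on the number. Compound 1 is recorded only as a limit, so the exact size of that step cannot be read: the limit of > 9000 nM in this assay, at which 1 of the 3 values shown sits.

The other step, with 5-carboxypentyl in place of vinyl, gives a 3.6-fold lower number from compound 2 to compound 3 (0.56 log units; beyond the scatter), which shows that a chain ending in a carboxy group can give a stronger inhibitor than the shorter unsubstituted ether of compound 2.

Going by these compounds, how the number moves at chain lengths shorter than that of compound 3, or at intermediate lengths on the way to compound 1, stays open. On these data alone, whether the carboxy end group itself is required also stays open, and a methyl ester, an amide or an amine at the chain end would address it.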